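Chloro to Methoxy: Expected Loss of Compound in Microsomes

A few compounds are considered here, and "the series" means these few. Any claim that something is new, unique, unknown or untested is made for them only; others in the source may bear on it.

Of the compounds shown here, three with a shared core have been measured in an ADME assay (liver) for metabolic stability, with Liver microsome (Homo sapiens) as the target, using microsomes, with a stated time of 1 h; a higher number here means that more of the compound is left, a lower number that less of the compound is left. Compound 1 `O=[N+]([O-])c1cn2c(n1)OC[C@@H](OCc1ccc(-c3ccc(OC(F)(F)F)cc3)cc1Cl)C2` gives 99%, the top of the three numbers, although both others lie within the usual scatter of it. Compound 3 `O=[N+]([O-])c1cn2c(n1)OC[C@@H](OCc1ccc(-c3ccc(OC(F)(F)F)cc3)c(F)c1)C2` gives 97% and compound 2 `O=[N+]([O-])c1cn2c(n1)OC[C@@H](OCc1ccc(-c3ccc(C(F)(F)F)cn3)cc1F)C2` gives 90%. Compound 4 `COc1cc(-c2ccc(OC(F)(F)F)cc2)ccc1CO[C@@H]1COc2nc([N+](=O)[O-])cn2C1` has not yet been measured. It differs from compound 1 by methoxy in place of chloro on an aromatic carbon, a methoxy in place of chloro on an aromatic carbon. Within the data shown here, no measured pair shows this change, so its effect is unknown. Compound 4 is expected to remain near its neighbours, with an expected step of a number 5 percentage points lower from compound 1 to compound 4 (within the scatter) that should stay within the scatter. Compound 4 is estimated at 94%, between 82% and 100%.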

Compound 4, percent of the compound remaining: 88%
Compound 4: the middle estimate sits 6 percentage points above what was measured; measured number inside the range.
By their numbers in this assay, from the lowest: compounds 4, 2, 3 and 1 (each within the scatter of the next, the first and the last beyond it).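

On the aromatic carbon ortho to a large group and meta to a large group, the swap of methoxy in place of chloro gives in this assay a number 11 percentage points lower from compound 1 to compound 4 (beyond the scatter) and so a modest change. Among these compounds, this is the first pair to show that the read-out responds to what sits at this position. Nothing available explains the change.

On these data alone, whether the step is particular to methoxy stays open, since no other group, such as an amine or a hydroxyl, appears at this position. As far as these compounds go, whether it recurs with a different group at the far end of the molecule also stays open.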